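Anilide Aryl Swap: Methyl to Methoxy on the Shared Core

A few compounds are considered here, and "the series" means these few. Any claim that something is new, unique, unknown or untested is made for them only; others in the source may bear on it.

Compound 1 `COc1cc(-c2nnc(SCC(=O)c3ccccc3)n2N)cc(OC)c1OC`: in a functional assay on PC-3 cells (Homo sapiens) for antiproliferative activity, read by MTT assay, with a stated time of 48 h (a lower number here means a stronger inhibitor, a higher number a weaker inhibitor), compound 1 reaches only the limit > 100000 nM.
Compound 2 `COc1cc(-c2nnc(SCC(=O)Nc3ccc(C)cc3)n2N)cc(OC)c1OC`: in this assay compound 2 gives 43100 nM.

Of the compounds shown here, two with a shared core have been measured. Compound 1 carries phenyl on the carbonyl carbon and its result in this assay is a limit, not a number. Compound 2 holds the (4-methylphenyl)amino group on that carbonyl carbon and supplies the only real number shown; the other value is a limit, (the limit of > 100000 nM in this assay, at which 1 of the 2 values shown sits). Among the compounds with values here, the one measured step is an at least 2.3-fold lower number from compound 1 to compound 2 (0.36 log units; beyond the scatter).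

Compound 3 `COc1cccc(NC(=O)CSc2nnc(-c3cc(OC)c(OC)c(OC)c3)n2N)c1` is the next compound to be measured. It differs from compound 2 by 3-methoxyphenyl in place of 4-methylphenyl on an amide-type nitrogen. Within the data shown here, no measured step alters a substituent on the aryl ring attached to the amide nitrogen; the only step, an at least 2.3-fold lower number from compound 1 to compound 2 (0.36 log units; beyond the scatter), concerns the group on the carbonyl carbon and does not bear directly on this change. The expectation for compound 3 is therefore no step beyond the usual scatter, a 1.0-fold higher number from compound 2 to compound 3 (0.02 log units; within the scatter). Compound 3 is estimated in this assay at 45000 nM, within 15000 nM to 150000 nM.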

Compound 3, half-maximal inhibitory concentration: > 100000 nM
Compound 3 gave a limit, no number (the forecaster's own chance of this, stated with the estimate: 25%); middle value at least 2.2-fold (0.34 log units) away from the limit.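

Within the data shown here, the step of an at least 2.3-fold higher number from compound 2 to compound 3 (0.36 log units; beyond the scatter) shows that in this assay the aryl group on the amide-type nitrogen matters: replacing 4-methylphenyl with 3-methoxyphenyl takes the compound out of the measurable range, and no earlier step had touched this group. The result for compound 3 is a limit, not a number, and the step from compound 1 to compound 3 cannot be read. The amide-type nitrogen alone therefore does not secure a measurable result, since compound 3 keeps that nitrogen and its carbonyl, leaving compound 2 as the only one of the three with a real number: the limit of > 100000 nM in this assay, at which 2 of the 3 values shown sit.

This single swap changes both the substituent and its numbered place on the ring, so the compounds shown cannot tell whether the methoxy group or its place accounts for the step. They also leave open how an unsubstituted phenyl or a ring bearing a carboxylic acid on that same nitrogen would read in this assay.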